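The compounds below may be only part of what the source reports. "The series", "measured", "known", "first", "only" and "open" are said of these compounds alone.

Compound 1 `CC1=C/C(=C\C(C)C)C(=O)C(C)(O)C12CC2` gives 30 nM in a functional assay on SW480 cells (Homo sapiens) for antiproliferative activity; on this read-out higher numbers stand for weaker inhibition and lower numbers for stronger inhibition. Compound 2 `CC1=C/C(=C\C#CCCO)C(=O)C(C)(O)C12CC2` gives 4000 nM in this assay, the higher of the two numbers, reached with a 130-fold higher number from compound 1 to compound 2 (2.12 log units; beyond the scatter). Compound 3 `C=C/C=C1\C=C(C)C2(CC2)C(C)(O)C1=O` differs from compound 2 by vinyl in place of 4-hydroxybut-1-yn-1-yl on a double-bonded chain carbon bound to a double-bonded ring carbon. Going by the values given here, the only step that bears on this position is that from compound 1 to compound 2, which was large in this assay, so with the donor and acceptor leaving again a large step back toward compound 1 is expected, though not the whole way. Compound 3 is estimated at 150 nM, with a range from 30 nM to 800 nM. This expectation means a 27-fold lower number from compound 2 to compound 3 (1.43 log units; beyond the scatter).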

Compound 3, half-maximal inhibitory concentration: 180 nM
The estimate for compound 3 lay 1.2-fold (0.08 log units) below the measured number, and the stated range covers the measured number.
By their numbers in this assay, from the lowest: compound 1; then compound 3; then compound 2.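

The step of a 22-fold lower number from compound 2 to compound 3 (1.35 log units; beyond the scatter) in this assay shows that much of the loss seen with 4-hydroxybut-1-yn-1-yl is recovered with vinyl at this position. The step of a 6.0-fold higher number from compound 1 to compound 3 (0.78 log units; beyond the scatter) shows that vinyl and isopropyl are also not interchangeable here, so this position responds to more than the 4-hydroxybut-1-yn-1-yl change. No measured evidence accounts for either step.

Still open, going by these compounds, is whether the loss with compound 2 follows the triple bond, the hydroxyl or the chain length. A but-1-yn-1-yl group without the hydroxyl, or an ethyl group, would help separate these.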